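A few compounds are considered here, and "the series" means these few. Any claim that something is new, unique, unknown or untested is made for them only; others in the source may bear on it.

Measured so far in this series:
- compound 1, `N=C(N)c1ccc(O)c(/C=C/CNc2ccc(OC3CCN(C(N)=O)CC3)c(C(F)(F)F)c2)c1`: 520 nM in an assay on isolated protein for inhibition of serine protease 1 (Bos taurus); on this read-out higher numbers stand for weaker inhibition and lower numbers for stronger inhibition
- compound 2, `CC(=N)N1CCC(Oc2ccc(NC/C(C)=C/c3cccc(C(=N)N)c3)cc2[N+](=O)[O-])CC1`: 5 nM

For the measured compounds named here, compound 1 stands at the highest of the two numbers in this assay; the only other measured compound, compound 2, sits a long way lower, a gap that is beyond the scatter, though compound 2 differs from compound 1 in several places at once, so no single change can be read from that pair.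

Compound 3, `CC(=N)N1CCC(Oc2ccc(NC/C=C/c3cc(C(=N)N)ccc3O)cc2C(F)(F)F)CC1`, is not yet measured. It differs from compound 1 in one place: a group of 3 heavy atoms (2 carbon, 1 nitrogen; no ring) in place of a group of 3 heavy atoms (1 carbon, 1 nitrogen, 1 oxygen; no ring), on an amine nitrogen in a ring. The entering group is the same one that compound 2 carries on its ring nitrogen, but compound 2 also differs elsewhere, so its value only hints at the direction.

Going by the values given here, with no single-change step available, the expectation rests on that hint: a marked drop in the number, well beyond the scatter, is expected for the step of a 21-fold lower number from compound 1 to compound 3 (1.32 log units; beyond the scatter). Compound 3 is estimated at 25 nM, with a plausible range from 5 nM to 120 nM.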

Compound 3, inhibition constant: 200 nM
Estimate against measurement, compound 3: 8.0-fold (0.90 log units) below; measured number above the stated range.
By their numbers in this assay, from the lowest: compound 2; then compound 3; then compound 1.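

For the compounds shown here, this is the only single-change reading so far at the amine nitrogen of the six-membered non-aromatic ring: in this assay, replacing carbamoyl with the group of 3 heavy atoms (2 carbon, 1 nitrogen) gives a 2.6-fold lower number from compound 1 to compound 3 (0.41 log units; beyond the scatter), a modest step. The two groups match in the counts computed for them, with 3 heavy atoms, 1 double bond outside aromatic rings, 1 hydrogen-bond donor, 1 hydrogen-bond acceptor and no net charge, so the number at this position responds to a change that leaves all of these counts the same. Nothing on hand accounts for the step, which stands as an observation without an explanation.

On these data alone, with one step on one core, it remains open whether the same replacement would give a step of similar size on the core of compound 2, where the other differences could alter the outcome. Also open, as far as these compounds go, is how this nitrogen would read with a hydrogen, a methyl or an acetyl on it, and so which feature of the entering group the step depends on.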